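Swapping a Methoxy for an Isopropyl on the Aryl Ring

A few compounds are considered here, and "the series" means these few. Any claim that something is new, unique, unknown or untested is made for them only; others in the source may bear on it.

Measured so far:
compound 1 `COc1ccc(N2C(=O)C(C)(C)c3cccnc32)cc1` — 63%
compound 2 `CC1(C)C(=O)N(c2cccc(C(F)(F)F)c2)c2ncccc21` — 35%

Of the compounds shown here, two sharing one core have been tested in a functional assay on the whole organism (Pleural cavity) for inhibition, with Rattus norvegicus as the target, at a dose of 25 mg/kg; a lower number here means less inhibition, a higher number more inhibition at the dose given (going by the name of the read-out). Compound 1 gives 63% in this assay, the higher of the two numbers. Compound 2 gives 35% in this assay, a number well below that of compound 1, beyond the usual scatter. Since compound 2 differs from compound 1 at more than one place, these two values alone do not say which change matters.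

Compound 3 `CC(C)c1ccc(N2C(=O)C(C)(C)c3cccnc32)cc1` has not yet been measured. It differs from compound 1 in one place: isopropyl in place of methoxy on an aromatic carbon. Within the data shown here, with no single-change step between measured compounds to lean on, the step from compound 1 to compound 3 is expected to be a modest fall, a number 13 percentage points lower from compound 1 to compound 3 (beyond the scatter), though a result within the scatter would not surprise. Compound 3 is therefore estimated to give 50% in this assay, in the range 30% to 70%.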

Compound 3, a percentage reported as inhibition, in the whole organism at one dose (the size of the read-out at that dose, not a potency): 29%
Beside the measured number, compound 3's estimate is 21 percentage points above it; the whole stated range lies above it.
By their numbers in this assay, from the lowest: compounds 3 and 2 (each within the scatter of the next); then compound 1.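

Among these compounds, this is the first change that can be read on its own. In this assay, isopropyl in place of methoxy on the aromatic carbon para to a large group gives a number 34 percentage points lower from compound 1 to compound 3 (beyond the scatter). With the rest of the molecule unchanged, this one swap moves the read-out by a large margin, so the group at this position clearly matters, and methoxy gives the higher number of the two; nothing at hand explains the difference.

Still open, going by these compounds, is whether the oxygen of methoxy counts or the number of atoms in the group: ethoxy, which keeps the oxygen, and methyl or ethyl, which lack it, would help separate the two. The trifluoromethyl group of compound 2 cannot be judged from this step, as compound 2 differs from compound 1 at more than one place.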